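Swapping chloro for fluoro in compound 2

This account rests on a few compounds, and the source may have more. Where it says the series, first, only, none or still open, it means among the compounds named here.

- Compound 1 `Cc1nc(N(C)c2ccc([Se]C#N)c(C)c2)c2ccccc2n1` gives 16 nM
- Compound 2 `Cc1nc(N(C)c2ccc([Se]C#N)c(Cl)c2)c2ccccc2n1` gives 9 nM
- Compound 3 `C[Se]c1ccc(N(C)c2nc(C)nc3ccccc23)cc1Cl` gives 7 nM

These numbers come from a functional assay on MDA-MB-231 cells (Homo sapiens) for inhibition, read by MTT assay, with a stated time of 48 h; a higher number here means a weaker inhibitor, a lower number a stronger inhibitor. Compound 2, at 9 nM, cannot be separated from the other two compounds, since both of its steps stay within the usual scatter of repeated measurements.

The next compound is compound 4 `Cc1nc(N(C)c2ccc([Se]C#N)c(F)c2)c2ccccc2n1`, which differs from compound 2 as follows: fluoro in place of chloro on an aromatic carbon. Put simply, this is fluoro in place of chloro on an aromatic carbon.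

The most relevant evidence is a 1.8-fold lower number from compound 1 to compound 2 (0.25 log units; within the scatter), where chloro replaced methyl on an aromatic carbon. That step stayed within the scatter. The other measured step, a 1.3-fold lower number from compound 2 to compound 3 (0.11 log units; within the scatter), changes the group on selenium, so it says little about this swap. Neither step gives a reason to expect a clear shift in this assay in either direction, so no step beyond the scatter is expected.

The estimated change is a 1.2-fold higher number from compound 2 to compound 4 (0.09 log units; within the scatter). For compound 4 the expected value is 11 nM, with an estimated range from 5 nM to 25 nM.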

Compound 4, half-maximal inhibitory concentration: 6 nM
Compound 4: the middle estimate sits 1.8-fold (0.26 log units) above what was measured; the range from low to high includes it.
By their numbers in this assay, from the lowest: compounds 4, 3, 2 and 1 (each within the scatter of the next, the first and the last beyond it).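

In this assay, fluoro in place of chloro gives a 1.5-fold lower number from compound 2 to compound 4 (0.18 log units; within the scatter), so at this position, ortho to a group of 3 heavy atoms, these two halogens cannot be told apart. The same position does show a change beyond the scatter when fluoro is compared with methyl, although a modest one: a 2.7-fold lower number from compound 1 to compound 4 (0.43 log units; beyond the scatter), the only step among these compounds to clear the scatter. No measurement shown here explains this difference.

The compounds shown leave open whether a plain hydrogen, a methoxy group or an amine at this position would give a number in the same range. Going by these compounds, it also remains open whether fluoro here would behave the same way with methyl rather than cyano on the selenium.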